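The source may hold more compounds than are shown below. What is called first, only, known or untested is meant among the compounds shown, and "the series" means these compounds.

Measured compounds:
- compound 1, `CNC(=O)C1CCCC1n1cnc2c(N)ncnc21`: 25%
- compound 2, `CNC(=O)C1CC=CC1n1cnc2c(N)ncnc21`: 22%
- compound 3, `CNC(=O)C1CCCC1n1cnc2c(NC3CC3)ncnc21`: < 10%, which is a limit of the assay and not a number

The read-out throughout is an assay on cell membranes for displacement of a labelled ligand from adenosine receptor A1 (Rattus norvegicus), tested at 100 uM; on this read-out higher numbers stand for more inhibition at the one concentration tested (going by the name of the read-out) and lower numbers for less inhibition. Compound 1 and compound 2 give numbers, while compound 3 sits at the limit (the limit of < 10% in this assay, at which 1 of the 3 values shown sits), so for compound 3 only a limit is known and not a value. For the measured compounds named here, the one measured step that leads to compound 3 is a number at least 15 percentage points lower from compound 1 to compound 3 (beyond the scatter), so adding a cyclopropyl on the nitrogen on the aromatic ring lowered the read-out beyond the scatter.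

The unmeasured compound 4 is `CNC(=O)C1CCCC1n1cnc2c(NC3CCCC3)ncnc21`. It differs from compound 3 by cyclopentyl in place of cyclopropyl on a nitrogen on an aromatic ring. Going by the values given here, no measured pair shows a change from one ring to a larger ring on that nitrogen, so the only guide is that compound 3 already stands at the limit. An expectation for compound 4 can therefore reach no lower than that limit, and nothing shown supports a rise beyond the scatter. The expected step is a number no lower from compound 3 to compound 4 (the limit leaves the size open), that is none beyond the scatter. In this assay compound 4 is expected to give about 10%, with a range from 0% to 25%.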

Compound 4, a percentage reported as inhibition, at one concentration (the size of the read-out at that concentration, not a potency): 31%
Compound 4: middle estimate off by 21 percentage points, on the low side; measured number outside the range, above it.
By their numbers in this assay, from the lowest: compounds 2, 1 and 4 (each within the scatter of the next). At a limit, below all of these: compound 3.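

In this assay, for the compounds shown here, the earlier compounds showed only a loss when a cyclopropyl was placed on the nitrogen on the aromatic ring, and the new step, a number at least 21 percentage points higher from compound 3 to compound 4 (beyond the scatter), shows that this loss does not carry over to every ring at this position. Compared with hydrogen on that nitrogen, the change is a number 6 percentage points higher from compound 1 to compound 4 (within the scatter), so among the compounds shown this position takes a cyclopentyl with no difference that can be told from the scatter, and only the cyclopropyl compound stands apart. The first step gives only a lower bound on the size of the rise, because compound 3 stands at a limit of the assay and not at a number: the limit of < 10% in this assay, at which 1 of the 4 values shown sits.

Going by these compounds, what a cyclobutyl or a cyclohexyl would give on this nitrogen remains open, so two rings do not yet amount to a trend with ring size. Also open, on these data alone, are whether an open chain such as n-pentyl would match the cyclopentyl, and whether the cyclopentyl would give a similar result on the core of compound 2.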